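Swapping Allyloxy for (Methylsulfonyl)methyl: a Cytotoxicity Outlook

The compounds below may be only part of what the source reports. "The series", "measured", "known", "first", "only" and "open" are said of these compounds alone.

Measured so far in an ADME assay on L02 cells (Homo sapiens) for cytotoxicity, read by MTT assay; a lower number here means a stronger inhibitor, a higher number a weaker inhibitor:
compound 1, `C=CCOc1cc(/C=C/C(=O)c2ccc(OC)c3c2OC(C)(C)C=C3)ccc1OC`, gives > 20000 nM, a limit of the assay.
compound 2, `CCC(=O)Oc1cc(/C=C/C(=O)c2ccc(OC)c3c2OC(C)(C)C=C3)ccc1OC`, gives > 10000 nM, a limit of the assay.
compound 3, `COc1ccc(/C=C/C(=O)c2ccc(OC)c3c2OC(C)(C)C=C3)cc1OC(=O)C(C)C`, gives > 10000 nM, a limit of the assay.

Compound 1 stands only at a limit, and the other two values are limits as well; none of the three is a number. The shared core carries a substituted aromatic ring, and the three compounds differ only in the group on one oxygen of that ring.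

Compound 4, `COc1ccc(/C=C/C(=O)c2ccc(OC)c3c2OC(C)(C)C=C3)cc1CS(C)(=O)=O`, has not yet been measured. Its change from compound 1 is (methylsulfonyl)methyl in place of allyloxy on an aromatic carbon.

Among the compounds with values here, the steps that bear on this position are a step that the two limits leave unreadable from compound 1 to compound 2 and a step that the two limits leave unreadable from compound 1 to compound 3, and both are unreadable, as the limits the limit of > 10000 nM in this assay, at which 2 of the 3 values shown sit, and the limit of > 20000 nM in this assay, at which 1 of the 3 values shown sits, bracket them. Within the data shown here, every change made so far at this position has left the compound at a limit, so the expectation is that the change to compound 4 also produces no step readable beyond the scatter.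

Compound 4 is therefore expected to give 30000 nM, within 10000 nM to 100000 nM. The estimated step is a step that the limit leaves unreadable from compound 1 to compound 4, and most likely the assay will again report only a limit.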

Compound 4, half-maximal inhibitory concentration: > 10000 nM
Compound 4 gave a limit, no number (the forecaster's own chance of this, stated with the estimate: 85%); the middle value lies beyond the limit too.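

In this assay compound 4 gives > 10000 nM as a limit and not a number. Within the data shown here, compound 1, compound 2 and compound 3 also stand only at limits, so no step from any of them to compound 4 can be read. The compounds shown leave open what actual number any of the four would give, and whether changing the group at this position shifts the value at all.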